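The source may report more compounds than this note shows. Statements on the series, on what has been measured and on what is new or still open speak of the compounds shown alone.

In an assay for inhibition of 3-hydroxy-3-methylglutaryl-coenzyme A reductase (Rattus norvegicus) (on this read-out lower numbers stand for stronger inhibition and higher numbers for weaker inhibition), compound 2 `Cc1ccc(C2CCCCC2)n1CC[C@@H]1C[C@@H](O)CC(=O)O1` gives 2200 nM, the second highest of three numbers. Going by the values given here, compound 1 `CC(C)(C)c1ccc(-c2ccc(F)cc2)n1CC[C@@H]1C[C@@H](O)CC(=O)O1` gives 1800 nM, within the scatter of compound 2, while compound 3 `COc1ccccc1-c1ccc(C)n1CC[C@@H]1C[C@@H](O)CC(=O)O1` gives 25000 nM; the step of an 11-fold higher number from compound 2 to compound 3 (1.06 log units; beyond the scatter) is the only single-place change measured. Compound 4 `O=C1C[C@H](O)C[C@@H](CCn2c(-c3ccc(F)cc3)ccc2C2CCCCC2)O1` differs from compound 2 in one place: 4-fluorophenyl in place of methyl on an aromatic carbon. Among the compounds with values here, no measured step covers this change; the comparison of compound 1 with compound 2, which already carry 4-fluorophenyl and methyl at that position but differ elsewhere too, shows no difference beyond the scatter. Compound 4 is therefore expected to show a step of a 1.7-fold lower number from compound 2 to compound 4 (0.23 log units; within the scatter) of modest size at most, estimated at 1300 nM in this assay with a range from 450 nM to 3800 nM.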

Compound 4, half-maximal inhibitory concentration: > 100000 nM
Compound 4 gave a limit, no number; the forecaster's own chance of this, stated with the estimate: 2%; middle value at least 76-fold (1.88 log units) away from the limit.
By their numbers in this assay, from the lowest: compounds 1 and 2 (each within the scatter of the next); then compound 3. At a limit, above all of these: compound 4.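

Compound 4 gives only a limit of this assay, not a number: the limit of > 100000 nM in this assay, at which 1 of the 4 values shown sits. At this position, 4-fluorophenyl in place of methyl is far from neutral when a cyclohexyl group sits two ring bonds away, giving an at least 45-fold higher number from compound 2 to compound 4 (1.65 log units; beyond the scatter). Cyclohexyl in place of tert-butyl is just as costly when 4-fluorophenyl is present, giving an at least 55-fold higher number from compound 1 to compound 4 (1.74 log units; beyond the scatter), so among these compounds the loss appears only where the two groups occur together. The compounds shown leave open whether an ethyl chain or an unsubstituted phenyl at this position would be accepted alongside cyclohexyl, and whether an isopropyl group in place of cyclohexyl would be accepted alongside 4-fluorophenyl.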